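The compounds below may be only part of what the source reports. "The series", "measured", "known", "first", "only" and "open" are said of these compounds alone.

Measured in a functional assay on HCT-116 cells (Homo sapiens) for cytotoxicity, read by MTT assay, with a stated time of 72 h; on this read-out higher numbers stand for weaker inhibition and lower numbers for stronger inhibition:
- Compound 1 `Nc1cccc(Nc2c(C(=O)NCc3ccc(F)cc3)nc(Br)c3cccnc23)c1`: > 10000 nM (a limit)
- Compound 2 `O=C(NCc1ccc(F)cc1)c1nc(Br)c2cccnc2c1NCCCNc1c(C(=O)NCc2ccc(F)cc2)nc(Br)c2cccnc12`: > 20000 nM (a limit)
- Compound 3 `N[C@H]1CC[C@H](Nc2c(C(=O)NCc3ccc(F)cc3)nc(N3CCCCC3)c3cccnc23)CC1`: 8500 nM

Compound 1 has no exact number here, since > 10000 nM is a limit of the assay. Compound 2 also has only a limit, > 20000 nM. Going by the values given here, compound 3 is the only one with an exact number, 8500 nM.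

Compound 4 `O=C(NCc1ccc(F)cc1)c1nc(Br)c2cccnc2c1NCCO` keeps the core of compound 1 but swaps one group: 2-hydroxyethyl in place of 3-aminophenyl on a nitrogen on an aromatic ring. In words, this puts 2-hydroxyethyl in place of 3-aminophenyl on a nitrogen on an aromatic ring. Among the compounds with values here, no measured pair of compounds shows what a change at this place does in this assay, so the expectation is cautious. Within the data shown here, compound 3, at 8500 nM, is the one exact value available as a guide, and it gives no reason to expect a large gain. The expected change is small, with no direction beyond the scatter, and the estimated step is a step that the limit leaves unreadable from compound 1 to compound 4. Compound 4 is expected at about 14000 nM, with an estimated range of 5000 nM to 40000 nM.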

Compound 4, half-maximal inhibitory concentration: > 20000 nM
Compound 4 ended at the assay's limit; the forecaster's own chance of this, stated with the estimate: 55%; middle value at least 1.4-fold (0.15 log units) from the limit.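

Going by these compounds alone, compound 1 and compound 4 each have only a limit in this assay, not an exact number, and no step between them can be read. The compounds shown leave open whether 2-hydroxyethyl in place of 3-aminophenyl on this nitrogen changes cytotoxicity at all, and in which direction.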